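Dichloro-for-fluorochloro swap in a diarylalkyne series

This account rests on a few compounds, and the source may have more. Where it says the series, first, only, none or still open, it means among the compounds named here.

Measured so far:
compound 1 `CN(C)c1ccc(C#Cc2ccccc2Cl)cc1`: 31 nM
compound 2 `CN(C)c1ccc(C#Cc2c(F)cccc2Cl)cc1`: 19 nM

In a functional assay on LS174T cells (Homo sapiens) for antiproliferative activity, with a stated time of 4 days (on this read-out lower numbers stand for stronger inhibition and higher numbers for weaker inhibition), compound 2 gives the lowest number of the two, yet its step from compound 1 is only a 1.6-fold lower number from compound 1 to compound 2 (0.21 log units; within the scatter), so the two stand within the scatter. Compound 3 `CN(C)c1ccc(C#Cc2c(Cl)cccc2Cl)cc1` carries chloro in place of fluoro on an aromatic carbon. Among the compounds with values here, no measured step of this kind exists; only the halogen-for-hydrogen step from compound 1 to compound 2 bears on it, and that stayed within the scatter. A step of a 1.2-fold lower number from compound 2 to compound 3 (0.07 log units; within the scatter) in this assay is therefore expected, none beyond the scatter. Compound 3 is estimated at 16 nM, range 6 nM to 45 nM.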

Compound 3, half-maximal inhibitory concentration: 52 nM
The estimate for compound 3 lay 3.3-fold (0.51 log units) below the measured number; measured number outside the range, above it.
By their numbers in this assay, from the lowest: compounds 2, 1 and 3 (each within the scatter of the next, the first and the last beyond it).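

In this assay, within the data shown here, this position separates the two halogens: a 2.7-fold higher number from compound 2 to compound 3 (0.44 log units; beyond the scatter) is the first step beyond the scatter, and it is modest. Hydrogen and chloro at the same position stay closer, with a 1.7-fold higher number from compound 1 to compound 3 (0.22 log units; within the scatter) in the same assay, so only the fluoro and chloro compounds stand clearly apart. Nothing available bears on the reason for this gap. Open, going by these compounds, is how a non-halogen group at this position, such as methyl, methoxy or an amine, would read, and whether the gap between fluoro and chloro holds on another core.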